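Removing the amine arm from compound 3

The compounds below may be only part of what the source reports. "The series", "measured", "known", "first", "only" and "open" are said of these compounds alone.

Measured so far in a functional assay on BaF3 cells (Mus musculus) for inhibition, read by CCK-8 assay, with a stated time of 72 h; on this read-out higher numbers stand for weaker inhibition of growth and lower numbers for stronger inhibition of growth:
compound 1 `CC(=O)Nc1cc(Oc2ccc(NC(=O)Nc3ccc(CN4CCN(C)CC4)c(C(F)(F)F)c3)cc2)ncn1`: 50 nM
compound 2 `COc1ccc(CNc2cc(Oc3ccc(NC(=O)Nc4ccc(C)c(C(F)(F)F)c4)cc3)ncn2)cc1`: 1000 nM
compound 3 `CCN1CCN(Cc2ccc(NC(=O)Nc3ccc(Oc4cc(NC(C)=O)ncn4)cc3)cc2C(F)(F)F)CC1`: 38 nM

In this assay, among the compounds with values here, compound 1 and compound 3 sit close together: the only step between compounds that differ in one place, a 1.3-fold lower number from compound 1 to compound 3 (0.12 log units; within the scatter), is within the scatter, so neither can be called stronger than the other. Compound 2 gives a clearly higher number than both, but it differs from each in more than one place, so no single step explains that gap.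

Compound 4 `CC(=O)Nc1cc(Oc2ccc(NC(=O)Nc3ccc(C)c(C(F)(F)F)c3)cc2)ncn1` has not been measured. It differs from compound 3 by hydrogen in place of 4-ethylpiperazin-1-yl on a saturated chain carbon bound to an aromatic carbon. Within the data shown here, no measured step covers this change. The closest hint is compound 2, which also carries a plain methyl in place of the amine arm but has a different group on the shared core and gives 1000 nM; how much of its weak result comes from the methyl alone cannot be told. A modest rise in this assay is therefore expected, as the step of a 3.2-fold higher number from compound 3 to compound 4 (0.50 log units; beyond the scatter). Compound 4 is estimated at 120 nM, within a range from 30 nM to 500 nM.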

Compound 4, concentration for 50% growth inhibition: 3230 nM
Beside the measured number, compound 4's estimate is 27-fold (1.43 log units) below it, outside the stated range (above it).
By their numbers in this assay, from the lowest: compounds 3 and 1 (each within the scatter of the next); then compound 2; then compound 4.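

In this assay, within the data shown here, the amine arm matters far more than the earlier compounds could show: going to a plain methyl gives an 85-fold higher number from compound 3 to compound 4 (1.93 log units; beyond the scatter) and, with the 4-methylpiperazin-1-yl arm removed instead, a 65-fold higher number from compound 1 to compound 4 (1.81 log units; beyond the scatter) in the same direction. With the methyl held fixed, the group on the nitrogen also changes the result, though by less, as acetyl in place of 4-methoxybenzyl gives a 3.2-fold higher number from compound 2 to compound 4 (0.51 log units; beyond the scatter) on the same read-out. No measurement here explains why either change has this effect.

Still open, from the compounds shown here alone, is whether the whole piperazine ring is required, or whether a smaller amine such as dimethylamine or a morpholine ring on the same chain carbon would hold the lower numbers. The compounds shown also cannot tell how 4-methoxybenzyl on the nitrogen behaves when a piperazine arm is present.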